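A few compounds are considered here, and "the series" means these few. Any claim that something is new, unique, unknown or untested is made for them only; others in the source may bear on it.

Measured so far:
compound 1, `COc1ccc(C(=O)/C=C/c2ccc(-c3ccccc3)cc2)c2c1C=CC(C)(C)O2`: > 10000 nM
compound 2, `COc1ccc(C(=O)/C=C/c2cccc(C(F)(F)F)c2)c2c1C=CC(C)(C)O2`: 9330 nM

In a functional assay on SK-OV-3 cells (Homo sapiens) for antiproliferative activity, read by MTT assay, with a stated time of 24 h (on this read-out higher numbers stand for weaker inhibition and lower numbers for stronger inhibition), compound 1 reports only a limit, > 10000 nM. Within the data shown here, compound 2 is the one compound with a number in this assay, 9330 nM, a weak value. The other entry sits at the limit of > 10000 nM in this assay, at which 1 of the 2 values shown sits.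

Compound 3, `COc1ccc(C(=O)/C=C/c2cccc(O)c2)c2c1C=CC(C)(C)O2`, is not yet measured. It differs from compound 2 in one place: hydroxy in place of trifluoromethyl on an aromatic carbon. Among the measured compounds shown here, no measured step between compounds that differ in one place exists here, so no change beyond the scatter is expected; the step from a 1.2-fold lower number from compound 2 to compound 3 (0.07 log units; within the scatter) is estimated to be flat. Compound 3 is expected at about 8000 nM, between 3000 nM and 20000 nM.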

Compound 3, half-maximal inhibitory concentration: > 10000 nM
Compound 3 ended at the assay's limit; the forecaster's own chance of this, stated with the estimate: 35%; middle value at least 1.2-fold (0.09 log units) away from the limit.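

In this assay, hydroxy in place of trifluoromethyl on an aromatic carbon gives an at least 1.0-fold higher number from compound 2 to compound 3 (0.03 log units; that floor lies within the scatter), so bringing in a hydrogen-bond donor and acceptor at this position yields no gain in inhibition. Compound 3 gives only a limit, > 10000 nM, so the true size of the step cannot be read. Most of the series shown now rests at the ceiling of the assay: the limit of > 10000 nM in this assay, at which 2 of the 3 values shown sit.

As far as these compounds go, how far compound 3 lies past its limit remains open. So does whether an amine or a carboxylic acid on this aromatic carbon would give a stronger value.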